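The compounds below may be only part of what the source reports. "The series", "measured", "known", "first", "only" and "open" are said of these compounds alone.

Going by the values given here, compound 2 `CCCSC1=C(C)C(=O)c2ccccc2C1=O` is the stronger of the two compounds measured so far in a functional assay on Hep 3B2 cells (Homo sapiens) for inhibition; on this read-out lower numbers stand for stronger inhibition and higher numbers for weaker inhibition. In this assay compound 2 gives 14 uM, whereas compound 1 `CCCCC1=C(C)C(=O)c2ccccc2C1=O` gives 78 uM. Among the compounds with values here, the single measured step, a 5.6-fold lower number from compound 1 to compound 2 (0.75 log units; beyond the scatter), exchanges a butyl group for a propylsulfanyl group on the double-bonded ring carbon of the shared core.

Compound 3 `CCCCSC1=C(C)C(=O)c2ccccc2C1=O` has not yet been measured. It differs from compound 2 by methyl in place of hydrogen on a saturated chain carbon, three bonds along the chain from a sulfur, that is, the propylsulfanyl chain of compound 2 is lengthened to a butylsulfanyl chain while the sulfur linkage is retained.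

Within the data shown here, no measured step covers a lengthening of this chain by a single methyl; the step from compound 1 to compound 2 concerns the exchange of a carbon for a sulfur at the point of attachment, not the length of the chain, and so bears on the present change only in showing that the sulfur-linked chain is the better of the two series. For compound 3 the account therefore expects a step of a 1.2-fold lower number from compound 2 to compound 3 (0.07 log units; within the scatter) that stays within the usual scatter, and an estimated value of 12 uM, with a range from 5 uM to 30 uM.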

Compound 3, concentration for 50% inhibition: 15 uM
Compound 3: middle estimate off by 1.3-fold (0.10 log units), on the low side; the range from low to high includes it.
By their numbers in this assay, from the lowest: compounds 2 and 3 (each within the scatter of the next); then compound 1.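

In this assay, going by these compounds alone, the lengthening of the propylsulfanyl chain to a butylsulfanyl chain comes out as a 1.1-fold higher number from compound 2 to compound 3 (0.03 log units; within the scatter) and so stays inside the scatter, which is the first reading of chain length in the sulfur-linked series: on a saturated chain carbon, three bonds along the chain from a sulfur, methyl in place of hydrogen leaves the read-out where it was. The earlier step changed the chain as well as the linkage, whereas attaching the butyl chain through a sulfur gives a 5.2-fold lower number from compound 1 to compound 3 (0.72 log units; beyond the scatter) and beyond the scatter, with a butyl chain present in both compounds. The data offer no explanation for either result.

The compounds shown leave open whether the read-out stays the same with a longer chain such as hexylsulfanyl, with a branched chain such as isobutylsulfanyl, or with a chain ending in an amine or a carboxylic acid. They also leave open how a propyl chain attached directly to the double-bonded ring carbon would compare with the butyl chain of compound 1.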